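Methyl on the core: a step between two inactive limits

The compounds below may be only part of what the source reports. "The series", "measured", "known", "first", "only" and "open" are said of these compounds alone.

Compound 2, `O=c1cc(CC(O)COCc2ccccc2)[nH]c(=O)[nH]1`, carries the shared core with a hydroxylated chain bearing one (benzyloxy)methyl group. In a functional assay on MCF7 cells (Homo sapiens) for antiproliferative activity, read by MTT assay, with a stated time of 72 h (on this read-out higher numbers stand for weaker inhibition and lower numbers for stronger inhibition), compound 2 reaches only the limit of the assay, > 100000 nM, and no number is read. Its neighbour compound 1, `O=c1cc(CC(O)(COCc2ccccc2)COCc2ccccc2)[nH]c(=O)[nH]1`, carries two such groups on the same chain. In this assay compound 1 likewise stops at the limit, > 100000 nM. The step between them, a step that the two limits leave unreadable from compound 1 to compound 2, therefore has no readable size. Among the compounds with values here, the only evidence available is the limit of > 100000 nM in this assay, at which 2 of the 2 values shown sit, which says nothing about how far beyond the limit either compound lies.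

Compound 3, `Cc1c(CC(O)COCc2ccccc2)[nH]c(=O)[nH]c1=O`, differs from compound 2 by methyl in place of hydrogen on an aromatic carbon. Within the data shown here, no measured step speaks to a change of this kind, and the one step available, from two limits to two limits, gives no size at all. With both measured values sitting at the limit, the expectation for compound 3 is that it also stays at or near the limit, with an estimated step that the limit leaves unreadable from compound 2 to compound 3. Compound 3 is thus expected at 150000 nM, within a range from 30000 nM to 1000000 nM.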

Compound 3, half-maximal inhibitory concentration: > 100000 nM
Compound 3: a limit, no number; the forecaster's own chance of this, stated with the estimate: 85%; the middle value does not contradict the limit.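

In this assay compound 3 stops at the limit > 100000 nM and gives no number. Compound 2 also stops at a limit, so the step between compound 2 and compound 3 cannot be read. The compounds shown leave open whether methyl in place of hydrogen on an aromatic carbon changes the activity at all, and what real potency compound 1, compound 2 and compound 3 have.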